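The source may hold more compounds than are shown below. What is called first, only, known or untested is meant among the compounds shown, and "the series" means these compounds.

Working notes on the series. Compound 1 `COC1=C(C)C(=O)/C(=C(O)/C=C/c2ccc(F)cc2)C(=O)C1(C)C` and compound 2 `COC1=C(C)C(=O)/C(=C(O)/C=C/c2cccc3ccccc23)C(=O)C1(C)C` share one core and differ only in the group on a double-bonded chain carbon bound to a double-bonded chain carbon. In a functional assay on HUVEC cells (Homo sapiens) (on this read-out lower numbers stand for an effect already at smaller amounts and higher numbers for an effect only at larger amounts of compound), compound 1 gives < 4 ug/mL, which is a limit of the assay and not a number. In this assay compound 2 gives < 4 ug/mL, again a limit rather than a number. Compound 1 therefore stands at the limit of < 4 ug/mL in this assay, at which 2 of the 2 values shown sit; no step between measured compounds is available, and nothing separates compound 1 from compound 2 on the numbers shown. Compound 3 `COC1=C(C)C(=O)/C(=C(O)/C=C/c2cccs2)C(=O)C1(C)C` carries thiophen-2-yl in place of 4-fluorophenyl on a double-bonded chain carbon bound to a double-bonded chain carbon. For the step from compound 1 to compound 3 in this assay no shift beyond the scatter is expected, and the reading is expected to sit at the same limit more often than not. Compound 3 is estimated at 2 ug/mL, with a range from 0.5 ug/mL to 6 ug/mL. The expected step is a step that the limit leaves unreadable from compound 1 to compound 3.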

Compound 3, concentration for half-maximal effect: < 4 ug/mL
Compound 3 gave a limit, no number; the forecaster's own chance of this, stated with the estimate: 70%; the middle value does not contradict the limit.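

Compound 1 and compound 3 both give a limit and not a number in this assay, so no step between them can be read: the limit of < 4 ug/mL in this assay, at which 3 of the 3 values shown sit.

The compounds shown leave open whether the groups on the double-bonded chain carbon differ at all in this assay.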